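Removing One Methoxy Group: From Compound 1 to Compound 4

The source may hold more compounds than are shown below. What is called first, only, known or untested is meant among the compounds shown, and "the series" means these compounds.

Measured compounds:
compound 1 `COc1cc(-c2cc(/C=C/C(=O)c3ccc(N)cc3)[nH]n2)cc(OC)c1OC` — 94%
compound 2 `COc1ccc(-c2cc(/C=C/C(=O)c3ccc(OC)c(OC)c3)[nH]n2)cc1` — 102%
compound 3 `COc1cc(-c2cc(/C=C/C(=O)c3ccc(Cl)c(Cl)c3)[nH]n2)cc(OC)c1OC` — 94%

All three were tested in a functional assay on 786-0 cells (Homo sapiens) for cytotoxicity, read by sulforhodamine B assay, with a stated time of 48 h, tested at 0.1 uM; on this read-out higher numbers stand for a weaker effect at the one concentration tested and lower numbers for a stronger effect. Compound 1 and compound 3 share the same reading, and compound 2 sits within the scatter of both, so the three numbers cannot be told apart.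

Within the data shown here, the only single change measured so far, no change at the digits printed from compound 1 to compound 3 (within the scatter), swaps the group on the carbonyl carbon at the far end of the molecule. It touches neither the ring that changes here nor its methoxy groups, but it shows that the one alteration recorded left the number where it was. Compound 2 differs from compound 1 in more than one place, so its value can only be taken as a second reading at the same level.

Compound 4 `COc1ccc(-c2cc(/C=C/C(=O)c3ccc(N)cc3)[nH]n2)cc1OC` is compound 1 with hydrogen in place of methoxy on an aromatic carbon. Among the measured compounds shown here, since every compound so far reads near the top of the scale, and the one measured step is flat, the step of a number 2 percentage points higher from compound 1 to compound 4 (within the scatter) is expected to stay within the scatter. Compound 4 is therefore estimated at 96%, between 85% and 106%.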

Compound 4, a percentage reported as activity, at one concentration (the size of the read-out at that concentration, not a potency): 95%
The estimate for compound 4 lay 1 percentage points above the measured number; the measured number falls inside the stated range.
By their numbers in this assay, from the lowest: compounds 1, 3, 4 and 2 (each within the scatter of the next).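

In this assay, among these compounds, the earlier single step changed only the group on the carbonyl carbon, whereas this is the first to alter the methoxy-bearing ring: hydrogen in place of methoxy gives a number 1 percentage points higher from compound 1 to compound 4 (within the scatter). At this position, on an aromatic carbon ortho to one methoxy group and meta to another, the loss of a methoxy group therefore cannot be told apart from no change at the single concentration tested. Nothing here bears on why the reading stays level.

The compounds shown leave open whether a different group at this position, such as a hydroxyl group or a fluorine atom, would shift the reading beyond the scatter. They also leave open whether removing either remaining methoxy group would do so.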